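Removing one methoxy group from a tri-methoxy ring

A few compounds are considered here, and "the series" means these few. Any claim that something is new, unique, unknown or untested is made for them only; others in the source may bear on it.

Compound 1 `COc1ccc(-c2cc(/C=C/C(=O)c3ccc(N)cc3)[nH]n2)cc1` and compound 2 `COc1ccc(-c2cc(/C=C/C(=O)c3ccc(N)cc3)[nH]n2)cc1OC` share a core; in a functional assay on HCT-15 cells (Homo sapiens) for cytotoxicity, read by sulforhodamine B assay, with a stated time of 48 h, tested at 10 uM (on this read-out higher numbers stand for a weaker effect at the one concentration tested and lower numbers for a stronger effect), compound 1 gives -40% and compound 2 gives -27%. The change hydrogen in place of methoxy on an aromatic carbon gave the step of a number 13 percentage points lower from compound 2 to compound 1 (beyond the scatter). Compound 3 `COc1cc(C(=O)/C=C/c2cc(-c3cc(OC)c(OC)c(OC)c3)n[nH]2)cc(OC)c1OC` has a different core; the difference between the two cores is not broken down here. In this assay compound 3 gives -71%, the lowest of the three. Compound 4 `COc1ccc(-c2cc(/C=C/C(=O)c3cc(OC)c(OC)c(OC)c3)[nH]n2)cc1OC` is made from compound 3 by hydrogen in place of methoxy on an aromatic carbon. This is the same kind of change as from compound 2 to compound 1, but not the same: here the place is also meta to a methoxy group. Because the earlier step was a number 13 percentage points lower from compound 2 to compound 1 (beyond the scatter), a step of similar size and direction is expected, a number 9 percentage points lower from compound 3 to compound 4 (within the scatter). Compound 4 is therefore estimated at -80%, between -96% and -58%.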

Compound 4, a percentage reported as activity, at one concentration (the size of the read-out at that concentration, not a potency): -41%
For compound 4 the middle estimate is 39 percentage points below the measured one, outside the stated range (above it).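

In this assay, hydrogen in place of methoxy on an aromatic carbon gave a number 30 percentage points higher from compound 3 to compound 4 (beyond the scatter), so the effect of this change on one core cannot simply be carried over to the other, in size or in direction: the same change on two cores in this assay, a number 13 percentage points lower (beyond the scatter) from compound 2 to compound 1 and a number 30 percentage points higher (beyond the scatter) from compound 3 to compound 4, 43 percentage points apart, beyond the scatter of two such steps The result does not show why the two steps part, since the cores differ and the surroundings of the changed place may differ too. Two steps also give no rule for this series as a whole.

The compounds shown leave open how the change would behave on further cores. They also leave open whether an ethoxy group or an amine at the same place would follow either step.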